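This account rests on a few compounds, and the source may have more. Where it says the series, first, only, none or still open, it means among the compounds named here.

In a functional assay on Raji cells (Homo sapiens) for cytotoxicity, read by CCK-8 assay, with a stated time of 24 h (a higher number here means a weaker inhibitor, a lower number a stronger inhibitor), three compounds on a shared core have been measured so far. Compound 1 (`C=CC(=O)N1C(=O)CC(c2ccc(OC)cc2)Sc2ccccc21`) gives 43300 nM and compound 2 (`C=CC(=O)N1C(=O)CC(c2ccc([N+](=O)[O-])cc2)Sc2ccccc21`) gives 34800 nM on this scale. Compound 3 (`C=CC(=O)N1C(=O)CC(c2ccccc2)Sc2ccccc21`) stands at 74100 nM and so is level, within the scatter, with compound 1, and modestly weaker only than compound 2. Compound 4 (`C=CC(=O)N1C(=O)CC(c2ccc(C(=O)OC)cc2)Sc2ccccc21`) differs from compound 3 by methoxycarbonyl in place of hydrogen on an aromatic carbon in the form of methoxycarbonyl in place of hydrogen on an aromatic carbon, para to a large group. The closest guides are two measured steps that swap a group on that carbon for hydrogen, to be read backwards: a 1.7-fold higher number from compound 1 to compound 3 (0.23 log units; within the scatter) for methoxy and a 2.1-fold higher number from compound 2 to compound 3 (0.33 log units; beyond the scatter) for nitro. Both point the same way, though only the second exceeds the scatter. Placing a group there is therefore expected to lower the number slightly, if at all. The estimated step is a 1.8-fold lower number from compound 3 to compound 4 (0.25 log units; within the scatter) and it may not clear the scatter. For compound 4 the estimated value is 42000 nM with an expected range from 22000 nM to 78000 nM in all.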

Compound 4, half-maximal inhibitory concentration: 89600 nM
Compound 4: middle estimate off by 2.1-fold (0.33 log units), on the low side; measured number outside the range, above it.
By their numbers in this assay, from the lowest: compounds 2, 1, 3 and 4 (each within the scatter of the next, the first and the last beyond it).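

In this assay, methoxycarbonyl on an aromatic carbon, para to a large group, gives a 1.2-fold higher number from compound 3 to compound 4 (0.08 log units; within the scatter), so this group cannot be told apart from hydrogen, and a substituent on this carbon does not by itself bring a lower number. The choice of group does matter here: methoxycarbonyl in place of nitro gives a 2.6-fold higher number from compound 2 to compound 4 (0.41 log units; beyond the scatter), and methoxycarbonyl in place of methoxy gives a 2.1-fold higher number from compound 1 to compound 4 (0.32 log units; beyond the scatter). Nothing available explains why these groups differ.

From the compounds shown here alone, it remains open whether a carboxylic acid or an amine on the same carbon would sit with nitro or with methoxycarbonyl. Going by these compounds, it is also open whether any group here can take the number well below that of compound 2, at 34800 nM.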